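The source may report more compounds than this note shows. Statements on the series, on what has been measured and on what is new or still open speak of the compounds shown alone.

Values in a functional assay on HCT-116 cells (Homo sapiens) for inhibition, with a stated time of 72 h; a higher number here means a weaker inhibitor, a lower number a stronger inhibitor:

- compound 1 `CC(C)[C@H]1CC[C@@]2(CO2)[C@H]2C(=O)OCC(C(=O)OCc3ccc(-c4ccc([N+](=O)[O-])cc4)o3)=C[C@H]12`: 620 nM
- compound 2 `CC(C)[C@H]1CC[C@@]2(CO2)[C@H]2C(=O)OCC(C(=O)OCc3ccc(-c4ccccc4)o3)=C[C@H]12`: 220 nM
- compound 3 `CC(C)[C@H]1CC[C@@]2(CO2)[C@H]2C(=O)OCC(C(=O)O)=C[C@H]12`: 210 nM

Compound 3 gives the lowest number of the three, yet its gap to compound 2 is within the scatter; only compound 1 stands apart from it, beyond the scatter. Compound 4 `COC(=O)C1=C[C@@H]2[C@@H](C(C)C)CC[C@@]3(CO3)[C@H]2C(=O)OC1` differs from compound 3 by methyl in place of hydrogen on an oxygen next to a carbonyl group. For the measured compounds named here, the one measured step, a 2.8-fold lower number from compound 1 to compound 2 (0.45 log units; beyond the scatter), concerns hydrogen in place of nitro on an aromatic carbon and does not touch the oxygen changed here, so it bears on compound 4 only loosely. What compound 2 and compound 3 show is that an ester and the free carboxy sit within the scatter of each other. The step of a 1.2-fold higher number from compound 3 to compound 4 (0.08 log units; within the scatter) is therefore expected to stay within the scatter. Compound 4 is estimated at 250 nM, with a range of 100 nM to 650 nM.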

Compound 4, half-maximal inhibitory concentration: 2190 nM
The estimate for compound 4 lay 8.8-fold (0.94 log units) below the measured number; the measured number lies above the stated range.
By their numbers in this assay, from the lowest: compounds 3 and 2 (each within the scatter of the next); then compound 1; then compound 4.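

In this assay, the carboxy to methoxycarbonyl change at this oxygen is far from silent: the step of a 10-fold higher number from compound 3 to compound 4 (1.02 log units; beyond the scatter) comes from a single added carbon on otherwise identical structures. For the compounds shown here, none of the earlier steps touched this oxygen, so this is the first direct reading of it, and it shows that the free carboxy cannot be capped with methyl without a large change in the number. Nothing measured here accounts for this step.

Open, on these data alone, is whether an ethyl ester or a primary amide in this place would read like compound 4 or like compound 3.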